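The compounds below may be only part of what the source reports. "The series", "measured", "known", "first", "only" and "open" are said of these compounds alone.

Measured compounds: compound 1 `CNC(=O)Cn1nc(N)c2c(C(F)(F)F)cc(-c3ccccc3)nc21` gives 11800 nM; compound 2 `CCNC(=O)Cn1nc(N)c2c(C(F)(F)F)cc(-c3ccccc3)nc21` gives 21300 nM; compound 3 `Nc1nn(CC(=O)NCC(=O)O)c2nc(-c3ccccc3)cc(C(F)(F)F)c12` gives 21200 nM, all in a functional assay on MCF7 cells (Homo sapiens) for cytotoxicity, read by MTT assay, with a stated time of 24 h; a lower number here means a stronger inhibitor, a higher number a weaker inhibitor.

Compound 1 and compound 2 differ by methyl in place of hydrogen on a saturated chain carbon bound to an amide-type nitrogen, and the step of a 1.8-fold higher number from compound 1 to compound 2 (0.26 log units; within the scatter) stays within the scatter. Compound 4 `CC(NC(=O)Cn1nc(N)c2c(C(F)(F)F)cc(-c3ccccc3)nc21)C(=O)O` is unmeasured. The core of compound 3 differs from that of compound 1 by carboxy in place of hydrogen on a saturated chain carbon bound to an amide-type nitrogen. Compound 3 becomes compound 4 through (methyl in place of hydrogen on a saturated chain carbon bound to an amide-type nitrogen and a carbonyl carbon), the same kind of change as from compound 1 to compound 2, but here the carbon also bears a carbonyl carbon, so the two changes are not the same. Compound 4 is expected to give a step of a 1.3-fold higher number from compound 3 to compound 4 (0.12 log units; within the scatter), resting on the small step seen from compound 1 to compound 2 a 1.8-fold higher number from compound 1 to compound 2 (0.26 log units; within the scatter). Compound 4 is therefore estimated at 28000 nM in this assay.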

Compound 4, half-maximal inhibitory concentration: 19900 nM
Estimate against measurement, compound 4: 1.4-fold (0.15 log units) above; low and high end bracket the measured number.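

In this assay, methyl in place of hydrogen on the chain carbon gives a 1.1-fold lower number from compound 3 to compound 4 (0.03 log units; within the scatter), and the same change on the two cores agrees within the scatter: the same change on two cores in this assay, a 1.8-fold higher number (0.26 log units; within the scatter) from compound 1 to compound 2 and a 1.1-fold lower number (0.03 log units; within the scatter) from compound 3 to compound 4, 1.9-fold (0.28 log units) apart, within the scatter of two such steps. Carboxy in place of hydrogen reads the same way, with a 1.1-fold lower number from compound 2 to compound 4 (0.03 log units; within the scatter) set beside its earlier counterpart: the same change on two cores in this assay, a 1.8-fold higher number (0.25 log units; within the scatter) from compound 1 to compound 3 and a 1.1-fold lower number (0.03 log units; within the scatter) from compound 2 to compound 4, 1.9-fold (0.28 log units) apart, within the scatter of two such steps. The remaining step, a 1.7-fold higher number from compound 1 to compound 4 (0.23 log units; within the scatter), also lies within the scatter, so the compounds show that neither change exceeds the scatter on either core, but not that either has a size or direction that carries from one core to another.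

From the compounds shown here alone, it remains open whether an amine or a longer chain at this chain carbon would give a step beyond the scatter.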